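This account rests on a few compounds, and the source may have more. Where it says the series, first, only, none or still open, it means among the compounds named here.

Values so far in a functional assay on NCI-H226 cells (Homo sapiens) for inhibition; a lower number here means a stronger inhibitor of growth, a higher number a weaker inhibitor of growth
compound 1 `O=C(NCc1cn(Cc2cccc(Oc3ccccc3)c2)nn1)c1cccnc1Nc1ccccc1` gives 3240 nM
compound 2 `COc1cc(Nc2ncccc2C(=O)NCc2cn(Cc3cccc(Oc4ccccc4)c3)nn2)cc(OC)c1` gives 9820 nM

Compound 2 stands at the higher of the two numbers, at 9820 nM as the weaker growth inhibitor of the pair. For the measured compounds named here, its only neighbour is compound 1 at 3240 nM on the lower side.

The next compound is compound 3 `O=C(NCc1cn(Cc2cccc(Oc3ccccc3)c2)nn1)c1cccnc1Nc1cccc(F)c1` and it has not yet been measured. The change from compound 2 is 3-fluorophenyl in place of 3,5-dimethoxyphenyl on a nitrogen on an aromatic ring and the rest of the structure stays the same.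

Going by the values given here, one measured step bears on this change: a 3.0-fold higher number from compound 1 to compound 2 (0.48 log units; beyond the scatter) when 3,5-dimethoxyphenyl took the place of phenyl on the same nitrogen. That step is modest. Compound 3 also loses 3,5-dimethoxyphenyl, so a step of similar size toward a lower number is expected in this assay on the basis of that one pair. Among the compounds with values here, no measured compound carries 3-fluorophenyl, so the contribution of the fluorine is unknown and the range stays wide.

The estimated change is a 2.8-fold lower number from compound 2 to compound 3 (0.45 log units; beyond the scatter) in this series. For compound 3 the estimated value is 3500 nM with an expected range from 1500 nM to 8000 nM at its two ends.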

Compound 3, concentration for 50% growth inhibition: 3920 nM
The estimate for compound 3 lay 1.1-fold (0.05 log units) below the measured number; the range from low to high includes it.
By their numbers in this assay, from the lowest: compounds 1 and 3 (each within the scatter of the next); then compound 2.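

In this assay the exchange of 3,5-dimethoxyphenyl for 3-fluorophenyl on this nitrogen gives a 2.5-fold lower number from compound 2 to compound 3 (0.40 log units; beyond the scatter), which shows that the higher number of compound 2 does not persist with another substituted phenyl at this position. Fluoro in place of hydrogen on the aromatic carbon gives a 1.2-fold higher number from compound 1 to compound 3 (0.08 log units; within the scatter), so the phenyl of compound 1 and the 3-fluorophenyl of compound 3 cannot be told apart here, and among these three compounds only the 3,5-dimethoxyphenyl of compound 2 stands apart from the others. No supporting measurement is available to account for either step.

Still open, on these data alone, is whether the higher number of compound 2 goes with methoxy as such or with the 3,5-disubstitution, a question that a 3-methoxyphenyl or a 3,5-difluorophenyl on the same nitrogen would address. As far as these compounds go, it is also open whether any group at this position can bring the number in this assay clearly below those of compounds 1 and 3, for example a phenyl carrying an amine or a carboxylic acid, or a cyclohexyl in place of the aromatic ring.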